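Compound 4: Expected Potency of the 4-Methylpyridin-2-yl Analogue

The source may hold more compounds than are shown below. What is called first, only, known or untested is meant among the compounds shown, and "the series" means these compounds.

For the measured compounds named here, compound 3 `CCOc1cc2oc(=O)n(CCC(=O)O)c2cc1Cl` gives 5.01 nM in an assay for inhibition of kynurenine 3-monooxygenase (Homo sapiens), read by mass spectrometry, with a stated time of 1 h (on this read-out lower numbers stand for stronger inhibition and higher numbers for weaker inhibition), the highest of the three numbers measured so far. Compound 1 `C[C@@H](Oc1cc2oc(=O)n(CCC(=O)O)c2cc1Cl)c1ccc(F)cn1` gives 2.51 nM, and compound 2 `C[C@@H](Oc1cc2oc(=O)n(CCC(=O)O)c2cc1Cl)c1cccnn1` gives 1.26 nM. Compound 4 `Cc1ccnc([C@@H](C)Oc2cc3oc(=O)n(CCC(=O)O)c3cc2Cl)c1` differs from compound 3 by 4-methylpyridin-2-yl in place of hydrogen on a saturated chain carbon bound to an oxygen on an aromatic ring and a saturated chain carbon. Going by the values given here, two measured steps bear on this change, both running the opposite way: a 2.0-fold higher number from compound 1 to compound 3 (0.30 log units; within the scatter) and a 4.0-fold higher number from compound 2 to compound 3 (0.60 log units; beyond the scatter). In both cases an aromatic ring at this position went with a small to modest drop in the number, so compound 4 is expected to land somewhat lower than compound 3 in this assay, with an estimated step of a 2.3-fold lower number from compound 3 to compound 4 (0.36 log units; beyond the scatter). Compound 4 is therefore expected to give about 2.2 nM, within a range from 0.9 nM to 5.5 nM.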

Compound 4, half-maximal inhibitory concentration: 3.98 nM
Estimate against measurement, compound 4: 1.8-fold (0.26 log units) below, within the range that was stated.
By their numbers in this assay, from the lowest: compounds 2, 1, 4 and 3 (each within the scatter of the next, the first and the last beyond it).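

With 4-methylpyridin-2-yl at this place, this assay shows a 1.3-fold lower number from compound 3 to compound 4 (0.10 log units; within the scatter), so a six-membered aromatic ring here need not move the number beyond the scatter from the compound without it. The ring's identity does matter, as the change from pyridazin-3-yl gives a 3.2-fold higher number from compound 2 to compound 4 (0.50 log units; beyond the scatter), whereas the change from 5-fluoropyridin-2-yl gives only a 1.6-fold higher number from compound 1 to compound 4 (0.20 log units; within the scatter). Nothing shown explains this difference. Still open, on these data alone, is how a phenyl ring or a pyrimidine ring would read on this saturated chain carbon, and whether an amine there would fit the same picture.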